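The source may hold more compounds than are shown below. What is called first, only, known or untested is meant among the compounds shown, and "the series" means these compounds.

Among the compounds with values here, compound 1 `COc1ccc(CN(C(=O)C2CC2)c2cc(OC)c(OC)c(OC)c2)cc1O` is the more active of the two compounds measured so far. In a functional assay on HCT-116 cells (Homo sapiens) for inhibition, read by MTT assay, with a stated time of 48 h (a lower number here means a stronger inhibitor, a higher number a weaker inhibitor), compound 1 gives 49 nM, the lower of the two numbers recorded. Within the data shown here, its only measured companion, compound 2 `COc1ccc(CNc2cc(OC)c(OC)c(OC)c2)cc1Br`, differs from it in more than one place and gives 48100 nM in this assay, a gap far beyond the scatter; no single step connects the two, so the data say only what those two values show. Compound 3 `COc1ccc(CN(C(=O)C(C)Br)c2cc(OC)c(OC)c(OC)c2)cc1O` has not yet been measured. It differs from compound 1 in one place: 1-bromoethyl in place of cyclopropyl on a carbonyl carbon. Among the measured compounds shown here, no measured pair shows the effect of such a change on the carbonyl carbon, so the expectation rests on compound 1 alone. The step from compound 1 to compound 3 in this assay is expected to be small, a 2.4-fold higher number from compound 1 to compound 3 (0.39 log units; beyond the scatter), leaning slightly toward a weaker inhibitor. Compound 3 is therefore estimated at 120 nM, within a range from 30 nM to 500 nM.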

Compound 3, half-maximal inhibitory concentration: 140 nM
Compound 3: the middle estimate sits 1.2-fold (0.07 log units) below what was measured; the range from low to high includes it.
By their numbers in this assay, from the lowest: compound 1; then compound 3; then compound 2.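

Within the data shown here, this is the first single change that can be read, and it shows that the group on the carbonyl carbon affects activity in this assay: 1-bromoethyl in place of cyclopropyl gives a 2.9-fold higher number from compound 1 to compound 3 (0.46 log units; beyond the scatter) and so a modest loss. The loss is limited, as compound 3 still gives 140 nM with no ring at this place, so the three-membered ring of carbon only is not required for sub-micromolar activity in this series. No measurement is available to explain the step.

The single step replaces the ring and introduces bromine together, so the compounds shown do not separate the two changes. As far as these compounds go, it remains open how an ethyl group, a cyclobutyl ring or a 1-chloroethyl group would read on the same carbonyl carbon.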